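The source may hold more compounds than are shown below. What is called first, only, known or untested is meant among the compounds shown, and "the series" means these compounds.

Working notes on a small series sharing the core of compound 1, `CC1(C)CCC(C)(C)c2cc(NC(=O)c3ccc(C(=O)OCCOC(=O)c4ccc(OCc5c(-c6ccccc6)no[n+]5[O-])cc4)cc3)ccc21`. In a functional assay on HL-60 cells (Homo sapiens) for antiproliferative activity, read by MTT assay, with a stated time of 48 h (on this read-out higher numbers stand for weaker inhibition and lower numbers for stronger inhibition), compound 1 gives 395000 nM. Compound 3, `CC1(C)CCC(C)(C)c2cc(NC(=O)c3ccc(C(=O)OCCCOC(=O)c4ccc(OCc5c(-c6ccccc6)no[n+]5[O-])cc4)cc3)ccc21`, differs from compound 1 only in the length of the ester-linked chain, and in this assay compound 3 gives 185000 nM. Compound 2, `C[C@H](NC(=O)c1ccc(C(=O)Nc2ccc3c(c2)C(C)(C)CCC3(C)C)cc1)C(=O)OCc1c(-c2ccccc2)no[n+]1[O-]`, replaces that chain with an amino-acid-derived link and is the most potent of the three: in this assay compound 2 gives 6970 nM, the lowest number of the set, with compound 3 nearest and compound 1 furthest, both separated from it by more than the usual scatter. For the measured compounds named here, no two measured compounds differ in a single place, so no isolated structural step can be read from the measured data.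

Compound 4, `CC(C)C[C@H](NC(=O)c1ccc(C(=O)Nc2ccc3c(c2)C(C)(C)CCC3(C)C)cc1)C(=O)OCc1c(-c2ccccc2)no[n+]1[O-]`, is the next member and has not yet been measured. Relative to compound 2 the change is isopropyl in place of hydrogen on a saturated chain carbon, two bonds along the chain from an amide-type nitrogen and a carbonyl carbon; cut one bond further out, the same difference reads methyl to isobutyl. Nothing in the measured set shows the effect of such a change, so the expectation rests on compound 2 alone. Compound 4 is expected to give about 6000 nM in this assay, with a range from 2500 nM to 15000 nM. The expected step is a 1.2-fold lower number from compound 2 to compound 4 (0.07 log units; within the scatter), none beyond the scatter.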

Compound 4, half-maximal inhibitory concentration: 740 nM
Compound 4: middle estimate off by 8.1-fold (0.91 log units), on the high side, and the stated range ends above it.
By their numbers in this assay, from the lowest: compound 4; then compound 2; then compound 3; then compound 1.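

In this assay, for the compounds shown here, the saturated chain carbon two bonds along the chain from an amide-type nitrogen and a carbonyl carbon responds to substitution: isopropyl in place of hydrogen, which reads as methyl to isobutyl when cut one bond further out, gives a 9.4-fold lower number from compound 2 to compound 4 (0.97 log units; beyond the scatter) and so provides the first single-place step. The entering group brings 3 heavy atoms, all carbon, with no ring, no hydrogen-bond donor or acceptor and no net charge, so at this position a purely carbon addition accompanies a step beyond the usual scatter. No measurement at hand bears on why the number falls with this change, and the step remains a single observation.

How a straight butyl chain, a benzyl group or a carboxylic acid on the same carbon would read remains open, so the compounds shown do not separate branching from the simple addition of carbon. Also open, from the compounds shown here alone, is how the mirror-image configuration at this carbon would read in this assay.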